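This account rests on a few compounds, and the source may have more. Where it says the series, first, only, none or still open, it means among the compounds named here.

Measured so far in an assay on isolated protein for inhibition of proto-oncogene tyrosine-protein kinase receptor Ret (Homo sapiens), read by radiometric assay and 33P incorporation, in the presence of a further agent that is not named here; on this read-out higher numbers stand for weaker inhibition and lower numbers for stronger inhibition:

- compound 1, `Nc1ncnc2c1c(-c1cc(C3CC3)on1)nn2C1CCCCC1`, gives 2 nM
- compound 2, `CCCCCCCn1nc(-c2cc(C3CC3)on2)c2c(N)ncnc21`, gives 96 nM
- compound 3, `Cn1nc(-c2cc(C3CC3)on2)c2c(N)ncnc21`, gives 27 nM

Compound 3 sits at the second highest of the three numbers in this assay. Its nearest neighbour is compound 2, the step of a 3.6-fold lower number from compound 2 to compound 3 (0.55 log units; beyond the scatter) being modest but beyond the scatter; its furthest is compound 1, where the step of a 14-fold higher number from compound 1 to compound 3 (1.13 log units; beyond the scatter) is large. The third step, a 48-fold higher number from compound 1 to compound 2 (1.68 log units; beyond the scatter), shows that an open heptyl chain on the same aromatic nitrogen does far worse than the six-membered ring of compound 1.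

Compound 4, `Nc1ncnc2c1c(-c1cc(C3CC3)on1)nn2C1CCOCC1`, carries the change (oxan-4-yl in place of methyl on an aromatic nitrogen). The entering oxan-4-yl is a six-membered non-aromatic ring with one oxygen, the closest analogue of the cyclohexyl of compound 1 within the series. The step that bears on this most directly is a 14-fold higher number from compound 1 to compound 3 (1.13 log units; beyond the scatter), read in reverse: a ring of six heavy atoms in place of methyl on that aromatic nitrogen gave a large downward move. For the measured compounds named here, the oxygen in the ring has no precedent here, so some allowance is made for it.

A large downward step, a 5.4-fold lower number from compound 3 to compound 4 (0.73 log units; beyond the scatter), is therefore expected. Compound 4 is estimated at 5 nM, with a range from 1.5 nM to 15 nM.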

Compound 4, half-maximal inhibitory concentration: 5 nM
For compound 4 middle estimate and measured number coincide at the digits printed; measured number inside the range.
By their numbers in this assay, from the lowest: compound 1; then compound 4; then compound 3; then compound 2.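

In this assay, a six-membered ring with one oxygen on this aromatic nitrogen keeps a clear advantage over both the small group and the open chain: oxan-4-yl improves on methyl (a 5.4-fold lower number from compound 3 to compound 4 (0.73 log units; beyond the scatter)) and, by a larger margin, on heptyl (a 19-fold lower number from compound 2 to compound 4 (1.28 log units; beyond the scatter)). The oxygen is not neutral, however, as replacing cyclohexyl with oxan-4-yl gives a modest rise that is beyond the scatter (a 2.5-fold higher number from compound 1 to compound 4 (0.40 log units; beyond the scatter)), so the two rings are not interchangeable at this position. Across the four compounds, both six-membered rings give lower numbers than methyl while heptyl gives a higher one, so heavy-atom count alone does not order the series, and no measurement here accounts for the gap between the two rings.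

Still open, from the compounds shown here alone, is whether a piperidin-4-yl ring, with an amine nitrogen in place of the ring oxygen, or a hydroxyl or carboxylic acid on the cyclohexyl ring, would stay closer to compound 1 or to compound 4. Smaller rings such as cyclopentyl or cyclobutyl would show how much of the six-membered ring is needed to hold the gain over methyl.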